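The compounds below may be only part of what the source reports. "The series", "measured", "known", "first", "only" and "open" are said of these compounds alone.

Measured compounds:
compound 1 `Cc1nc(-c2ccsc2)cc2nn(-c3ccccc3)cc12` — 10000 nM in a functional assay on K562 cells (Homo sapiens) for inhibition, read by fluorescence, with a stated time of 72 h; on this read-out higher numbers stand for weaker inhibition of growth and lower numbers for stronger inhibition of growth
compound 2 `c1ccc(-n2cc3cnc(-c4ccsc4)cc3n2)cc1` — 8300 nM in this assay

On the numbers shown, compound 1 and compound 2 sit inside the scatter of each other, a 1.2-fold lower number from compound 1 to compound 2 (0.08 log units; within the scatter), so neither can be set apart from the other. The step to compound 3 `Cc1nccc2nn(-c3ccccc3)cc12` is hydrogen in place of thiophen-3-yl on an aromatic carbon: the thiophen-3-yl, a five-membered aromatic ring with one hetero atom and one hydrogen-bond acceptor, leaves and only a hydrogen remains at that carbon. Within the data shown here, no measured step touches this position; the single measured step, a 1.2-fold lower number from compound 1 to compound 2 (0.08 log units; within the scatter), concerns the methyl and lies within the scatter, so it gives no guide to the size or direction of removing the thiophen-3-yl. Among the measured compounds shown here, with two weak compounds and no step on this point, the direction stays open and the range must be wide. Compound 3 is therefore expected near 15000 nM, between 4000 nM and 60000 nM, because compound 1 gives 10000 nM and nothing shown argues for a move beyond the scatter. This estimate means an expected step of a 1.5-fold higher number from compound 1 to compound 3 (0.18 log units; within the scatter).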

Compound 3, concentration for 50% growth inhibition: > 100000 nM
Compound 3 ended at the assay's limit; the forecaster's own chance of this, stated with the estimate: 35%; at least 6.6-fold (0.82 log units) between middle value and limit.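

Compound 1 and compound 2 both carry the thiophen-3-yl, so neither gave a reading on this position. Hydrogen in place of that group on the aromatic carbon next to the ring nitrogen now gives an at least 10-fold higher number from compound 1 to compound 3 (1.00 log units; beyond the scatter) in this assay, so inhibition of growth weakens beyond the scatter once the thiophen-3-yl is gone, and this position counts for more than the methyl does. For compound 3 the value is a limit of the assay and not a number: the limit of > 100000 nM in this assay, at which 1 of the 3 values shown sits.

Going by these compounds, whether this depends on the thiophene ring itself or on any group at this carbon stays open. A phenyl ring, a pyridine, an amine or a short alkyl chain at this carbon would separate these readings, and would show whether compound 1 can be improved from this position at all.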